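Expected potency of compound 4 after the side-group exchange

The compounds below may be only part of what the source reports. "The series", "measured", "known", "first", "only" and "open" are said of these compounds alone.

For the measured compounds named here, in a functional assay on A2780 cells (Homo sapiens) for antiproliferative activity, read by CellTiter-Glo, with a stated time of 72 h (a lower number here means a stronger inhibitor, a higher number a weaker inhibitor), three compounds have numbers so far.

- compound 1 `C[C@@H](c1ccc(NC(=O)N2CC(c3ccc(N)nc3)C2)cc1)N1Cc2ccccc2C1=O` gives 5.9 nM
- compound 2 `C[C@H](NC(=O)c1ncccn1)c1ccc(NC(=O)N2CC(c3ccc(N)nc3)C2)cc1` gives 68 nM
- compound 3 `C[C@@H](c1ccc(NC(=O)N2CC(c3cncc(N)c3)C2)cc1)N1Cc2ccccc2C1=O` gives 45 nM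

The data show a 7.6-fold higher number from compound 1 to compound 3 (0.88 log units; beyond the scatter) and so place compound 3 well away from compound 1 on this scale, while compound 3 and compound 2 sit within the usual scatter of each other. Compound 4 `C[C@H](NC(=O)c1ncccn1)c1ccc(NC(=O)N2CC(c3cncc(N)c3)C2)cc1` has not yet been measured. Its change from compound 3 is a group of 9 heavy atoms (5 carbon, 3 nitrogen, 1 oxygen; one six-membered aromatic ring with 2 hetero atoms) in place of a group of 10 heavy atoms (8 carbon, 1 nitrogen, 1 oxygen; one five-membered non-aromatic ring with 1 hetero atom, one six-membered aromatic ring of carbon only), on a saturated chain carbon bound to an aromatic carbon and a saturated chain carbon and the 5-aminopyridin-3-yl group stays in place. The same exchange has been measured once, with 6-aminopyridin-3-yl in the molecule, as a 12-fold higher number from compound 1 to compound 2 (1.06 log units; beyond the scatter) and that large step is the closest guide. The other measured step concerns the aminopyridine group, which is untouched here. Going by the values given here, no measured pair shows whether the exchange has the same size with 5-aminopyridin-3-yl present, so this single step is carried over with caution and trimmed slightly. The expected step in this assay is an 8.9-fold higher number from compound 3 to compound 4 (0.95 log units; beyond the scatter) and would be a large move to a higher number. For compound 4 the estimated value is 400 nM with an expected range from 130 nM to 1100 nM as the likely span.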

Compound 4, half-maximal inhibitory concentration: 340 nM
Compound 4: the middle estimate sits 1.2-fold (0.07 log units) above what was measured, and the stated range covers the measured number.
By their numbers in this assay, from the lowest: compound 1; then compounds 3 and 2 (each within the scatter of the next); then compound 4.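

In this assay, the entry of ((pyrimidin-2-yl)carbonyl)amino on the saturated chain carbon gives a 7.6-fold higher number from compound 3 to compound 4 (0.88 log units; beyond the scatter) with 5-aminopyridin-3-yl in the molecule, so the exchange keeps its size on a second core: the same change on two cores in this assay, a 12-fold higher number (1.06 log units; beyond the scatter) from compound 1 to compound 2 and a 7.6-fold higher number (0.88 log units; beyond the scatter) from compound 3 to compound 4, 1.5-fold (0.18 log units) apart, within the scatter of two such steps

The aminopyridine change can now also be read with ((pyrimidin-2-yl)carbonyl)amino in the molecule, as a 5.0-fold higher number from compound 2 to compound 4 (0.70 log units; beyond the scatter), and it too keeps its size: the same change on two cores in this assay, a 7.6-fold higher number (0.88 log units; beyond the scatter) from compound 1 to compound 3 and a 5.0-fold higher number (0.70 log units; beyond the scatter) from compound 2 to compound 4, 1.5-fold (0.18 log units) apart, within the scatter of two such steps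

Across these four compounds the two changes therefore act as independent steps, and no compound goes against this, although each comparison rests on only two steps.

The compounds shown leave open why either change moves the number, and whether another group on the saturated chain carbon, such as acetylamino or a primary amine, would stay close to compound 1 at 5.9 nM. They also do not tell how a pyridin-3-yl group without an amine, or a 6-methoxypyridin-3-yl group, would compare with 6-aminopyridin-3-yl on the saturated ring carbon.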